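The source may hold more compounds than are shown below. What is called first, only, known or untested is meant among the compounds shown, and "the series" means these compounds.

- compound 1 `CC(C)COc1ccc2oc(/C=C/[S+](C)[O-])cc(=O)c2c1` at 5000 nM
- compound 2 `C[S+]([O-])/C=C/c1cc(=O)c2cc(Cl)ccc2o1` at 6500 nM

Among the compounds with values here, in a functional assay on DLD-1 cells (Homo sapiens) for cytotoxicity, with a stated time of 48 h (on this read-out higher numbers stand for weaker inhibition and lower numbers for stronger inhibition), compound 2 at 6500 nM lies within the scatter of compound 1, the only other number. Compound 3 `CCC(=O)Oc1ccc2oc(/C=C/[S+](C)[O-])cc(=O)c2c1` has propanoyloxy in place of chloro on an aromatic carbon. Within the data shown here, the one measured step (a 1.3-fold higher number from compound 1 to compound 2 (0.11 log units; within the scatter)) also exchanged a group on an aromatic carbon and stayed within the scatter. No step beyond the scatter is therefore expected in this assay, though a single step is thin support. The expected step (a 1.2-fold lower number from compound 2 to compound 3 (0.07 log units; within the scatter)) is only an estimate. Compound 3 is expected at 5500 nM with an estimated range of 2000 nM to 15000 nM for now.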

Compound 3, half-maximal inhibitory concentration: 9000 nM
For compound 3 the middle estimate is 1.6-fold (0.21 log units) below the measured one, within the range that was stated.
By their numbers in this assay, from the lowest: compounds 1, 2 and 3 (each within the scatter of the next).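

At this position on the shared core, propanoyloxy now stands alongside chloro and isobutoxy, and in this assay no exchange among the three leaves the scatter: propanoyloxy for chloro (a 1.4-fold higher number from compound 2 to compound 3 (0.14 log units; within the scatter)) and propanoyl for isobutyl on the oxygen (a 1.8-fold higher number from compound 1 to compound 3 (0.26 log units; within the scatter)). Among these three compounds, five heavy atoms with two hydrogen-bond acceptors thus read no differently from a single chlorine. Nothing available explains this flat reading.
As far as these compounds go, whether an amine, a carboxylic acid or a longer chain at this position would produce a step beyond the scatter remains open.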